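The source may hold more compounds than are shown below. What is called first, only, known or untested is meant among the compounds shown, and "the series" means these compounds.

Measured in an ADME assay on BEMS cells (Bos taurus) for cytotoxicity; a higher number here means a weaker inhibitor, a lower number a stronger inhibitor:
- Compound 1 `CCCCC(C(=O)COc1c(F)c(F)cc(F)c1F)n1cc([C@](C)(CC(C)C)NCc2ccc3ncccc3c2)nn1`: > 10000 nM, a limit
- Compound 2 `CCC(C(=O)COc1c(F)c(F)cc(F)c1F)n1cc([C@](C)(CC(C)C)NCc2ccc3ncccc3c2)nn1`: > 10000 nM, a limit
- Compound 3 `CCCCC(C(=O)COc1c(F)c(F)cc(F)c1F)n1cc([C@@](C)(NCc2ccc3ncccc3c2)C2CCC2)nn1`: > 10000 nM, a limit

Compound 3 has only a limit and no number, and the same holds across the series: the limit of > 10000 nM in this assay, at which 3 of the 3 values shown sit. Compound 4 `CCC(C(=O)COc1c(F)c(F)cc(F)c1F)n1cc([C@@](C)(NCc2ccc3ncccc3c2)C2CCC2)nn1` carries hydrogen in place of ethyl on a saturated chain carbon, three bonds along the chain from an aromatic nitrogen and a carbonyl carbon, relative to compound 3 (hydrogen in place of ethyl on a saturated chain carbon, three bonds along the chain from an aromatic nitrogen and a carbonyl carbon). Among the compounds with values here, the one measured step with this change is a step that the two limits leave unreadable from compound 1 to compound 2, so it gives no size to carry over. The expected change is a step that the limit leaves unreadable from compound 3 to compound 4, with no step beyond the scatter expected in this assay. For compound 4 the estimate is 15000 nM, with an expected range from 7000 nM to 30000 nM.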

Compound 4, half-maximal inhibitory concentration: > 10000 nM
Compound 4 ended at the assay's limit; the forecaster's own chance of this, stated with the estimate: 90%; the middle value is on the limit's open side.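

Compound 4 also gives only a limit in this assay, so neither the step to it from compound 3 nor the step to it from compound 2 can be read. How compounds 1, 2, 3 and 4 truly differ stays open: the limit of > 10000 nM in this assay, at which 4 of the 4 values shown sit.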